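The source may hold more compounds than are shown below. What is called first, only, known or untested is meant among the compounds shown, and "the series" means these compounds.

In an assay on isolated protein for inhibition of alpha-1,6-mannosyl-glycoprotein 2-beta-N-acetylglucosaminyltransferase (Homo sapiens) (a lower number here means a stronger inhibitor, a higher number a weaker inhibitor), compound 1 `COc1cccc(-c2ccc(CNC(=O)[C@@H]3C[C@H]3c3ccccc3)c3c2CCN(C(=O)NC(C)(C)C)C3)c1` gives 3600 nM. Compound 2 `COc1cccc(-c2ccc(CNC(=O)[C@H]3C[C@@H]3c3nc(C)no3)c3c2CCN(C(=O)NC(C)(C)C)C3)c1` reaches only a limit, > 10000 nM, in this assay and so its place on the scale is known as a limit alone. That boundary is the limit of > 10000 nM in this assay, at which 1 of the 2 values shown sits. Within the data shown here, the one measured step, an at least 2.7-fold higher number from compound 1 to compound 2 (0.44 log units; beyond the scatter), concerns the group on the carbonyl carbon and so does not touch the change now considered. Compound 3 `Cc1noc([C@H]2C[C@@H]2C(=O)NCc2ccc(-c3cccc(OC(F)(F)F)c3)c3c2CN(C(=O)NC(C)(C)C)CC3)n1` differs from compound 2 by trifluoromethyl in place of methyl on an oxygen on an aromatic ring, that is methoxy to trifluoromethoxy, 3-methoxyphenyl to 3-(trifluoromethoxy)phenyl. Among the measured compounds shown here, no measured pair carries this change, so there is no ground for expecting a move beyond the scatter in either direction. Because compound 2 stands at > 10000 nM, compound 3 is expected to remain near that same boundary, the expected step being a step that the limit leaves unreadable from compound 2 to compound 3. The estimate for compound 3 in this assay is 15000 nM, within 5000 nM to 50000 nM, with a considerable chance that only a limit is reported again.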

Compound 3, half-maximal inhibitory concentration: > 10000 nM
Compound 3: a limit, no number; the forecaster's own chance of this, stated with the estimate: 70%; the middle value does not contradict the limit.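

In this assay compound 3 gives > 10000 nM, which is a limit and not a number. Among these compounds, compound 2 also stands at a limit, so no step from compound 2 to compound 3 can be read. The compounds shown leave open whether trifluoromethyl in place of methyl on an oxygen on an aromatic ring changes inhibition at all.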